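The source may hold more compounds than are shown below. What is called first, only, known or untested is meant among the compounds shown, and "the series" means these compounds.

In an in vitro functional assay on HEK293 cells for antagonist activity at melanin-concentrating hormone receptor 1 (Homo sapiens) (on this read-out higher numbers stand for larger maximal responses and lower numbers for smaller maximal responses), compound 1, `Cc1ccc(CN2CCC(CCN(Cc3ccc(-c4ccc(F)cc4)cc3)C(=O)NC(C)C)CC2)cc1`, gives 113%. Compound 2, `Cc1ccc(CN2CCC(CCN(Cc3ccc(-c4cccc(C#N)c4)cc3)C(=O)NC(C)C)CC2)cc1`, gives 97% in this assay, and compound 3, `Cc1ccc(CN2CCC(CCN(Cc3ccc(-c4ccc(F)cc4)cc3)C(=O)NC(C)(C)CO)CC2)cc1`, gives 102%. Compound 3 thus stands second highest of the three measured numbers: its value and that of compound 2 lie within the scatter of each other, while compound 1 sits above it by a step that is beyond the scatter, namely a number 11 percentage points lower from compound 1 to compound 3 (beyond the scatter).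

Compound 4, `Cc1ccc(CN2CCC(CCN(Cc3ccc(-c4cccc(C#N)c4)cc3)C(=O)NC(C)(C)CO)CC2)cc1`, has not been measured in this assay. It differs from compound 3 as follows: 3-cyanophenyl in place of 4-fluorophenyl on an aromatic carbon. The same exchange has been seen once before, going from compound 1 to compound 2, where it gave a number 16 percentage points lower from compound 1 to compound 2 (beyond the scatter). Within the data shown here, that single step is the only direct guide, and it points downward by a modest amount.

On this basis compound 4 is expected to come out somewhat lower than compound 3 in this assay, by an estimated a number 14 percentage points lower from compound 3 to compound 4 (beyond the scatter). The estimate for compound 4 is therefore 88%, with a likely range from 74% to 102%.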

Compound 4, largest response reached (reported as Imax), in percent of the reference or control that the assay uses: 99.3%
Estimate against measurement, compound 4: 11.3 percentage points below; the range from low to high includes it.
By their numbers in this assay, from the lowest: compounds 2, 4 and 3 (each within the scatter of the next); then compound 1.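

On the core of compound 3, the exchange of 4-fluorophenyl for 3-cyanophenyl in this assay gives a number 2.7 percentage points lower from compound 3 to compound 4 (within the scatter), so a step beyond the scatter on the core of compound 1 does not recur here, although the two steps cannot be told apart: the same change on two cores in this assay, a number 16 percentage points lower (beyond the scatter) from compound 1 to compound 2 and a number 2.7 percentage points lower (within the scatter) from compound 3 to compound 4, 13.3 percentage points apart, within the scatter of two such steps. The hydroxymethyl behaves in the same way, giving a number 2.3 percentage points higher from compound 2 to compound 4 (within the scatter), and again the two steps cannot be told apart: the same change on two cores in this assay, a number 11 percentage points lower (beyond the scatter) from compound 1 to compound 3 and a number 2.3 percentage points higher (within the scatter) from compound 2 to compound 4, 13.3 percentage points apart, within the scatter of two such steps. Each change thus gives a step beyond the scatter only when it starts from compound 1.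

On these data alone, whether either step depends on the core therefore remains open. So does the outcome of other groups, such as a carboxylic acid in place of the nitrile or an amine in place of the hydroxyl of the hydroxymethyl.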